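The source may report more compounds than this note shows. Statements on the series, on what has been measured and on what is new or still open speak of the compounds shown alone.

Compound 1 `CC(C)c1ccc(-c2nc(SCc3cn(CC(=O)NC(=O)Nc4ccccn4)nn3)nc(Nc3ccc(Cl)cc3)c2C#N)cc1`, compound 2 `CC(C)c1ccc(-c2nc(SCc3cn(CC(=O)NC(=O)Nc4ccccn4)nn3)nc(Nc3cccc(Cl)c3)c2C#N)cc1` and compound 3 `COc1cc(-c2nc(SCc3cn(CC(=O)NC(=O)Nc4ccccn4)nn3)nc(Nc3ccc(Cl)cc3)c2C#N)cc(OC)c1OC` share a core that carries a nitrile and a cyclic pendant on one side, and differ only in two rings fixed to that core. In a functional assay on B16-F10 cells (Mus musculus) for inhibition, read by MTT assay, with a stated time of 72 h (on this read-out higher numbers stand for weaker inhibition and lower numbers for stronger inhibition), compound 1 gives 860 nM, and in this assay compound 2 gives 1130 nM. The change between them is 3-chlorophenyl in place of 4-chlorophenyl on a nitrogen on an aromatic ring, and that step is a 1.3-fold higher number from compound 1 to compound 2 (0.12 log units; within the scatter). In this assay compound 3 gives 1110 nM, so that the change (3,4,5-trimethoxyphenyl in place of 4-isopropylphenyl on an aromatic carbon), which is how the core of compound 1 differs from the core of compound 3, made a step that is a 1.3-fold higher number from compound 1 to compound 3 (0.11 log units; within the scatter). The three measured values therefore sit close together.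

Compound 4 `COc1cc(-c2nc(SCc3cn(CC(=O)NC(=O)Nc4ccccn4)nn3)nc(Nc3cccc(Cl)c3)c2C#N)cc(OC)c1OC` is not yet measured. Compared with compound 3 it carries the change (3-chlorophenyl in place of 4-chlorophenyl on a nitrogen on an aromatic ring), which is the same change that was made from compound 1 to compound 2, and it sits at the same place; it has been seen only once. Because that earlier step is a 1.3-fold higher number from compound 1 to compound 2 (0.12 log units; within the scatter), the expectation is that the step from compound 3 to compound 4 in this assay will be of a similar modest size, a 1.3-fold higher number from compound 3 to compound 4 (0.10 log units; within the scatter), with the caveat that a single example on a different core is a thin basis. Compound 4 is thus expected to give about 1400 nM in this assay, most likely between 700 nM and 2800 nM.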

Compound 4, half-maximal inhibitory concentration: 1420 nM
Compound 4: middle estimate off by 1.0-fold (0.01 log units), on the low side; measured number inside the range.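

Moving the chlorine, with 3-chlorophenyl in place of 4-chlorophenyl, gave a 1.3-fold higher number from compound 3 to compound 4 (0.11 log units; within the scatter) in this assay, and the size of this step carried over from one core to the other: the same change on two cores in this assay, a 1.3-fold higher number (0.12 log units; within the scatter) from compound 1 to compound 2 and a 1.3-fold higher number (0.11 log units; within the scatter) from compound 3 to compound 4, 1.0-fold (0.01 log units) apart, within the scatter of two such steps

Putting 3,4,5-trimethoxyphenyl in place of 4-isopropylphenyl gave a 1.3-fold higher number from compound 2 to compound 4 (0.10 log units; within the scatter), and this change also behaved alike in the two settings: the same change on two cores in this assay, a 1.3-fold higher number (0.11 log units; within the scatter) from compound 1 to compound 3 and a 1.3-fold higher number (0.10 log units; within the scatter) from compound 2 to compound 4, 1.0-fold (0.01 log units) apart, within the scatter of two such steps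

Within the data shown here, since every one of these steps lies within the scatter, the agreement shows only that neither change produced a detectable shift on either core; it does not show that either change truly alters inhibition, or that the same would hold on a core beyond these four compounds.

The compounds shown leave open whether a larger change could produce a step beyond the scatter, such as an amine or a carboxylic acid in place of the chlorine, or a longer chain in place of the isopropyl group. They also leave open how far the cyclic pendant, which is the same in all four compounds, matters for the values seen in this assay, since a group held constant cannot reveal its own contribution.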